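Series notes: oxazole for thiazole, compound 2 to compound 3

The compounds below may be only part of what the source reports. "The series", "measured", "known", "first", "only" and "open" are said of these compounds alone.

For the measured compounds named here, compound 2 `CC(C)c1csc(-c2cccc(CNc3ccc4[nH]nc(C(=O)O)c4c3)c2O)n1` gives 65 nM in an assay on isolated protein for inhibition of 2-Hydroxyacid oxidase 1 (Homo sapiens), with stated times of 30 min and 15 min (a lower number here means a stronger inhibitor, a higher number a weaker inhibitor), the highest of the two numbers measured so far. Going by the values given here, compound 1 `CC(C)c1csc(-c2cccc(CN(C)c3ccc4[nH]nc(C(=O)O)c4c3)c2O)n1` gives 35 nM in this assay, and the one measured step, a 1.9-fold higher number from compound 1 to compound 2 (0.27 log units; within the scatter), is hydrogen in place of methyl on a nitrogen on an aromatic ring. Compound 3 `CC(C)c1coc(-c2cccc(CNc3ccc4[nH]nc(C(=O)O)c4c3)c2O)n1` keeps that hydrogen and differs from compound 2 only by 4-isopropyl-1,3-oxazol-2-yl in place of 4-isopropyl-1,3-thiazol-2-yl on an aromatic carbon, on an aromatic carbon ortho to a hydroxy group and meta to a large group. Among the compounds with values here, no measured pair differs in this way, so the known step gives no guide to the ring swap; the leaving and entering groups match in what is counted for them. The expectation is therefore a step of no more than the usual scatter, in no preferred direction: a 1.2-fold higher number from compound 2 to compound 3 (0.09 log units; within the scatter). Compound 3 is estimated at 80 nM, expected to fall within 30 nM to 250 nM.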

Compound 3, half-maximal inhibitory concentration in the 2-Hydroxyacid oxidase 1 assay: 87 nM
Beside the measured number, compound 3's estimate is 1.1-fold (0.04 log units) below it; the measured number falls inside the stated range.
By their numbers in the 2-Hydroxyacid oxidase 1 assay, from the lowest: compounds 1, 2 and 3 (each within the scatter of the next, the first and the last beyond it).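

At this position, on an aromatic carbon ortho to a hydroxy group, 4-isopropyl-1,3-oxazol-2-yl can stand in for 4-isopropyl-1,3-thiazol-2-yl with no readable loss in the 2-Hydroxyacid oxidase 1 assay: a 1.3-fold higher number from compound 2 to compound 3 (0.13 log units; within the scatter). In a physicochemical assay for solubility, measured as kinetic solubility, at pH 2 (a lower number here means a less soluble compound, a higher number a more soluble compound), compound 2 gives 97000 nM and compound 3 gives 4000 nM, so this single-atom change shows what the earlier step on the nitrogen could not: the two read-outs can part at this ring. In the physicochemical assay the thiazole is thus clearly the better of the two rings, and the oxazole carries a large solubility penalty: the measured solubility of compound 2, 97000 nM, and of compound 3, 4000 nM, a 24-fold lower number (1.38 log units; beyond the scatter)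

Going by these compounds, it remains open how a cyclopropyl or a tert-butyl in place of the isopropyl, or a pyrazole in place of the five-membered ring, would read in either assay. Also open, on these data alone, is whether the same ring swap gives the same large step in solubility with the methyl on the nitrogen of compound 1.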